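The source may report more compounds than this note shows. Statements on the series, on what has been measured and on what is new or still open speak of the compounds shown alone.

Compound 1 `O=C(CCc1cccc2c1B(O)OC2)NCc1ccccc1`: > 100000 nM
Compound 2 `O=C(CCc1cccc2c1B(O)OC2)Nc1nccs1`: > 100000 nM

In an ADME assay on WI-38 cells (Homo sapiens) for cytotoxicity, read by MTT assay, with a stated time of 72 h (a higher number here means a weaker inhibitor, a lower number a stronger inhibitor), compound 1 gives > 100000 nM, which is a limit of the assay and not a number. Compound 2 gives > 100000 nM, which is likewise a limit. Compound 2 therefore has no exact place on the scale, and it shares its position with compound 1: the limit of > 100000 nM in this assay, at which 2 of the 2 values shown sit.

The next compound, compound 3 `O=C(CCc1cccc2c1B(O)OC2)Nc1ccc(I)cc1`, carries 4-iodophenyl in place of 1,3-thiazol-2-yl on an amide-type nitrogen.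

Within the data shown here, only one measured step bears on this change, a step that the two limits leave unreadable from compound 1 to compound 2, and it offers no size to carry over. The expected step, an at least 1.2-fold lower number from compound 2 to compound 3 (0.09 log units; that floor lies within the scatter), is thus a cautious estimate, small and without a firm direction in this assay. For compound 3 the estimated value is 80000 nM, with an expected range of 25000 nM to 150000 nM.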

Compound 3, half-maximal inhibitory concentration: 49000 nM
The estimate for compound 3 lay 1.6-fold (0.21 log units) above the measured number; the range from low to high includes it.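

Among these compounds, with 4-iodophenyl on the amide-type nitrogen, compound 3 gives the first exact number in this assay, which shows that a change at this position can bring a compound within the measurable range of the assay. The other two compounds share one reading, which is a limit of the assay and not a number: the limit of > 100000 nM in this assay, at which 2 of the 3 values shown sit. The change can therefore be sized from one side only, as an at least 2.0-fold lower number from compound 2 to compound 3 (0.30 log units; that floor lies within the scatter) and as an at least 2.0-fold lower number from compound 1 to compound 3 (0.30 log units; that floor lies within the scatter), while the step from compound 1 to compound 2 cannot be read.

On these data alone, it remains open whether the iodine or the six-membered aromatic ring of carbon goes with the lower number. Plain phenyl or 4-chlorophenyl at this position would separate the two, and a carboxylic acid on the ring would test a very different group.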